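Replacing 3-acetylphenyl on the amine nitrogen: an estimate

A few compounds are considered here, and "the series" means these few. Any claim that something is new, unique, unknown or untested is made for them only; others in the source may bear on it.

Measured compounds:
compound 1, `CC1(C)Oc2ccc(C#N)cc2[C@@H](/N=C(\NC#N)NCc2ccccc2)[C@@H]1O`, 2400 nM
compound 2, `CC1(C)Oc2ccc(C#N)cc2[C@@H](NC(=O)Nc2ccccn2)[C@@H]1O`, 440 nM
compound 3, `CC(=O)c1cccc(N/C(=N/[C@@H]2c3cc(C#N)ccc3OC(C)(C)[C@H]2O)NC#N)c1`, 8400 nM

Of the compounds shown here, three that share one core have been tested in a functional assay (aorta) with Rattus norvegicus as the target; a higher number here means a weaker inhibitor, a lower number a stronger inhibitor. Compound 3 gives 8400 nM, the highest of the three numbers; its nearest neighbour is compound 1, and compound 2 with 440 nM lies furthest from it. Among the measured compounds shown here, the only single-point step among the measured compounds is the one from compound 1 to compound 3, a 3.5-fold higher number from compound 1 to compound 3 (0.54 log units; beyond the scatter), which shows that exchanging the group on this nitrogen can move the number by a modest but real amount.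

Compound 4, `CC1(C)Oc2ccc(C#N)cc2[C@@H](/N=C(\NC#N)Nc2ccc3c(c2)CCC3)[C@@H]1O`, has not yet been measured. It differs from compound 3 in one place: 2,3-dihydro-1H-inden-5-yl in place of 3-acetylphenyl on an amine nitrogen. For the measured compounds named here, no measured step covers this exchange directly, and the step from compound 1 to compound 3 changes both the attachment and the group, so it offers only a rough guide to how much the number may shift. On that basis compound 4 is expected to give a number close to that of compound 3, with at most a modest change, a 1.7-fold lower number from compound 3 to compound 4 (0.23 log units; within the scatter). Compound 4 is therefore estimated at 5000 nM in this assay, within a range from 1500 nM to 17000 nM.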

Compound 4, half-maximal inhibitory concentration: 41300 nM
Compound 4: the middle estimate sits 8.3-fold (0.92 log units) below what was measured, and the stated range ends below it.
By their numbers in this assay, from the lowest: compound 2; then compound 1; then compound 3; then compound 4.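

In this assay, 2,3-dihydro-1H-inden-5-yl in place of 3-acetylphenyl on the amine nitrogen gives a 4.9-fold higher number from compound 3 to compound 4 (0.69 log units; beyond the scatter) and so shows that this position still responds when the two groups have the same heavy-atom count and each carries a six-membered aromatic ring of carbon only. The exchange also removes the one hydrogen-bond acceptor and the double bond outside the aromatic ring that 3-acetylphenyl carries, and the number moves beyond the scatter. Measured against benzyl, the same group gives a 17-fold higher number from compound 1 to compound 4 (1.24 log units; beyond the scatter), a large step that exceeds the modest 3.5-fold higher number from compound 1 to compound 3 (0.54 log units; beyond the scatter) and places both directly attached ring groups above benzyl in this series; nothing available accounts for these shifts.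

From the compounds shown here alone, what a plain phenyl or a 3-aminophenyl group would give on this nitrogen stays open, so the contribution of the acetyl group cannot be separated from that of the ring that bears it. Going by these compounds, it is also open whether 2-phenylethyl would stay near compound 1, which gives 2400 nM with benzyl on this nitrogen.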